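Mirror Image of a Bridged Pyridine Agonist

The source may hold more compounds than are shown below. What is called first, only, known or untested is meant among the compounds shown, and "the series" means these compounds.

Of the compounds shown here, two have been measured in an in vitro functional assay on SH-EP1 cells for agonist activity at Neuronal acetylcholine receptor; alpha4/beta2 (Homo sapiens), read by voltage clamp; on this read-out lower numbers stand for smaller maximal responses and higher numbers for larger maximal responses. Compound 1, with the structure `CC(C)Oc1cncc(C2=CC3CC(C2)CN(C)C3)c1`, gives 10% in this assay. Compound 2, with the structure `C1=C(c2cccnc2)C[C@H]2CNC[C@@H]1C2`, gives 40% in this assay. Within the data shown here, of the two numbers, compound 2 has the higher one; the only other value, that of compound 1, lies a distance below it that goes beyond the usual scatter of such measurements. Compound 2 is thus the stronger of the pair on maximal response.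

Compound 3, with the structure `C1=C(c2cccnc2)C[C@@H]2CNC[C@H]1C2`, has not yet been measured. It differs from compound 2 as follows: the two compounds have the same atoms and bonds and differ only in configuration as drawn: 2 of 2 stereo elements differ (all stereocentres are inverted: mirror images); a stereocentre at a saturated ring carbon is drawn S in compound 2 and R in compound 3; a stereocentre at a saturated ring carbon is drawn R in compound 2 and S in compound 3. Among the measured compounds shown here, no pair of measured compounds shows what such a change does in this assay, so there is no measured step to lean on. For compound 3 the step from compound 2 is expected to be a number 5 percentage points lower from compound 2 to compound 3 (within the scatter), that is, no change beyond the scatter, but with wide uncertainty in either direction. Compound 3 is therefore estimated at 35% in this assay, within a range from 10% to 60%.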

Compound 3, largest response reached (reported as percent of maximum), in percent of the reference or control that the assay uses: 32%
Beside the measured number, compound 3's estimate is 3 percentage points above it; measured number inside the range.
By their numbers in this assay, from the lowest: compound 1; then compounds 3 and 2 (each within the scatter of the next).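

In this assay, among these compounds, inverting both stereocentres gives a number 8 percentage points lower from compound 2 to compound 3 (within the scatter), the first measured step between compounds that differ in one respect only. Within the usual scatter, this read-out does not separate the two mirror images, so in this pair the maximal response at the receptor shows no clear dependence on which hand of the bridged core is present. The step can be tied to a single kind of change, and the reason is simple: the fact that compounds 2 and 3 differ only in the configuration as drawn

The compounds shown leave open whether the two mirror images would also match on another measure, such as the concentration needed to reach that response, since only the largest response is reported here. They also leave open whether the match between mirror images would hold once the core carries a further group, such as a methoxy group or a primary amine, or a methyl group on the ring nitrogen, as a single change from compound 2 or compound 3.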